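Chloro for Methyl on a Weak Collagen Promoter Series

This account rests on a few compounds, and the source may have more. Where it says the series, first, only, none or still open, it means among the compounds named here.

Measured compounds:
compound 1, `Cc1ccc(-n2cc(C(=O)Nc3cc(F)cc(F)c3)c(=O)c3ccc(N(C)C)nc32)cc1OCCCCCCC[N+]12CCN(CC1)CC2`, 5.07%
compound 2, `CN(C)c1ccc2c(=O)c(C(=O)Nc3cc(F)cc(F)c3)cn(-c3ccc(Cl)c(OCCCCCCC[N+]45CCN(CC4)CC5)c3)c2n1`, 8.08%
compound 3, `Cc1cc(OCCCCCCC[N+]2(C)CCCCC2)ccc1-n1cc(C(=O)Nc2cc(F)cc(F)c2)c(=O)c2ccc(N(C)C)nc21`, "not active" (no number reported)

In an assay on LX2 cells for inhibition of COL1A1 promoter (Homo sapiens), read by a luciferase reporter, with a stated time of 24 h, tested at 20 uM (on this read-out higher numbers stand for a stronger effect at the one concentration tested and lower numbers for a weaker effect), compound 1 gives 5.07% and compound 2 gives 8.08%. The step of a number 3 percentage points higher from compound 1 to compound 2 (within the scatter) comes from the change (chloro in place of methyl on an aromatic carbon). Compound 3 is reported in this assay as "not active" (no number reported), with no number; the difference between its core and the core of compound 1 is not broken down here. Compound 4, `CN(C)c1ccc2c(=O)c(C(=O)Nc3cc(F)cc(F)c3)cn(-c3ccc(OCCCCCCC[N+]4(C)CCCCC4)cc3Cl)c2n1`, is not yet measured; it carries the change (chloro in place of methyl on an aromatic carbon), the same kind of change as from compound 1 to compound 2, though the place differs: here it is meta to a large group, there para to a large group. For compound 4 the expected outcome is 5%, between 0% and 15%, because a number 3 percentage points higher from compound 1 to compound 2 (within the scatter) lay within the scatter and compound 3 gave no measurable inhibition, so a low number or again no number is expected.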

Compound 4, a percentage reported as inhibition, at one concentration (the size of the read-out at that concentration, not a potency): "not active" (no number reported)
Compound 4: no number reported; the estimate stays without a comparison.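

Compound 3 and compound 4 are both reported without a number in this assay, so no step can be read between them. No other measurement shown bears on this result. The compounds shown leave open whether chloro in place of methyl at this place changes the read-out at all.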